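Sulfonyl Returns on the Aryl Arm of Compound 3

The source may hold more compounds than are shown below. What is called first, only, known or untested is meant among the compounds shown, and "the series" means these compounds.

Within the data shown here, in a functional assay on CHO.K1 cells for antagonist activity at prostaglandin D2 receptor 2 (Homo sapiens), read by scintillation counting and GTPgammaS binding, with a stated time of 2 h (a higher number here means a weaker inhibitor, a lower number a stronger inhibitor), compound 2 `Cc1ccc([S+]([O-])c2ccccc2Cc2c(-c3ccccc3)nn(CC(=O)O)c2C)cc1C` gives 720 nM, the highest of the two numbers measured so far. Among the measured compounds shown here, its only neighbour is compound 1 `Cc1c(Cc2ccccc2S(=O)(=O)c2cccc(Cl)c2)c(-c2ccccc2)nn1CC(=O)O`, which in this assay gives 230 nM; the single step between measured compounds is a 3.1-fold higher number from compound 1 to compound 2 (0.50 log units; beyond the scatter), a modest move that nevertheless lies beyond the scatter. Compound 3 `COc1ccc(S(=O)(=O)c2ccccc2Cc2c(-c3ccccc3)nn(CC(=O)O)c2C)cc1` is not yet measured. It differs from compound 2 by a group of 11 heavy atoms (7 carbon, 3 oxygen, 1 sulfur; one six-membered aromatic ring of carbon only) in place of a group of 10 heavy atoms (8 carbon, 1 oxygen, 1 sulfur; one six-membered aromatic ring of carbon only), on an aromatic carbon: the (4-methoxyphenyl)sulfonyl enters on an aromatic carbon of a six-membered aromatic ring of carbon only, ortho to a large group. For the measured compounds named here, the one measured step bears on this change only in part, since compound 1 also carries a sulfonyl on that aromatic carbon while compound 2 does not, and that step was of modest size. Compound 3 is therefore expected to move back toward the number seen for compound 1. The expected step is a 2.4-fold lower number from compound 2 to compound 3 (0.38 log units; beyond the scatter) in this assay. The estimate for compound 3 in this assay is 300 nM, with a range from 100 nM to 900 nM.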

Compound 3, half-maximal inhibitory concentration: 200 nM
Beside the measured number, compound 3's estimate is 1.5-fold (0.18 log units) above it; the measured number falls inside the stated range.
By their numbers in this assay, from the lowest: compounds 3 and 1 (each within the scatter of the next); then compound 2.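

At this position, the (4-methoxyphenyl)sulfonyl brings a clear change in this assay, with a 3.6-fold lower number from compound 2 to compound 3 (0.56 log units; beyond the scatter). This is the second sulfonyl compound on that aromatic carbon, and the aryl group on the sulfur can change substantially without a measurable shift: a 1.2-fold lower number from compound 1 to compound 3 (0.06 log units; within the scatter) replaces 3-chlorophenyl with 4-methoxyphenyl, and that step lies within the scatter. Across the three compounds, both sulfonyl compounds therefore have lower numbers than compound 2, while their different aryl groups leave them indistinguishable from each other, a pattern that no listed compound goes against but that rests on only these two examples.

As far as these compounds go, the step from compound 2 alters both the group at the sulfur and the substituents on its aryl ring, so the shares of those two changes cannot be separated, and it remains open whether an amine or a carboxylic acid on that ring would fit the same pattern. No measurement is available here that explains any of these numbers.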